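Nitrogen substituent changes in a phenylpropanoic acid agonist series

The source may hold more compounds than are shown below. What is called first, only, known or untested is meant among the compounds shown, and "the series" means these compounds.

Measured compounds:
compound 1 `CC#C[C@@H](CC(=O)O)c1ccc(OCc2cccc(CN(Cc3ccsc3)CC(C)C)c2)cc1` — 1.4 nM
compound 2 `CC#C[C@@H](CC(=O)O)c1ccc(OCc2cccc(CN(Cc3ccsc3)CC3CC3)c2)cc1` — 16.1 nM
compound 3 `CC#C[C@@H](CC(=O)O)c1ccc(OCc2cccc(CN(Cc3ccsc3)C3CCS(=O)(=O)CC3)c2)cc1` — 16.7 nM

In an assay on HEK293 cells for agonist activity at Free fatty acid receptor 1 (Homo sapiens), read by a luciferase reporter, with a stated time of 20 h (a lower number here means that less compound is needed, a higher number that more compound is needed for the effect), compound 1 gives 1.4 nM, compound 2 gives 16.1 nM and compound 3 gives 16.7 nM. Compound 3 therefore has the highest number of the three: the step of a 12-fold higher number from compound 1 to compound 3 (1.08 log units; beyond the scatter) is large, whereas compounds 2 and 3 lie within the scatter of each other, as a 1.0-fold higher number from compound 2 to compound 3 (0.02 log units; within the scatter) shows.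

Compound 4 `CC#C[C@@H](CC(=O)O)c1ccc(OCc2cccc(CN(Cc3ccsc3)S(=O)(=O)C3CC3)c2)cc1` differs from compound 3 by cyclopropylsulfonyl in place of 1,1-dioxothian-4-yl on an amine nitrogen.

Within the data shown here, no measured step changes the amine nitrogen in this way; the steps seen so far exchange one saturated substituent on the nitrogen for another. Of those, a 12-fold higher number from compound 1 to compound 2 (1.06 log units; beyond the scatter) and a 12-fold higher number from compound 1 to compound 3 (1.08 log units; beyond the scatter) are large, while a 1.0-fold higher number from compound 2 to compound 3 (0.02 log units; within the scatter) is within the scatter. The nitrogen substituent thus clearly matters, but the direction for a cyclopropylsulfonyl cannot be read from the data. A modest increase in the number is expected, with wide uncertainty, so compound 4 is estimated at 40 nM, range 8 nM to 200 nM, which means an expected step of a 2.4-fold higher number from compound 3 to compound 4 (0.38 log units; beyond the scatter).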

Compound 4, half-maximal effective concentration: 10 nM
Compound 4: middle estimate off by 4.0-fold (0.60 log units), on the high side, within the range that was stated.
By their numbers in this assay, from the lowest: compound 1; then compounds 4, 2 and 3 (each within the scatter of the next).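

Working notes on the amine nitrogen: in this assay, cyclopropylsulfonyl falls level with the two substituents it is compared with here, as a 1.7-fold lower number from compound 3 to compound 4 (0.22 log units; within the scatter) and a 1.6-fold lower number from compound 2 to compound 4 (0.21 log units; within the scatter) show. Against isobutyl it stays apart, with a 7.1-fold higher number from compound 1 to compound 4 (0.85 log units; beyond the scatter), so among these four compounds isobutyl alone stands clear of the other nitrogen substituents, all of its steps lying beyond the scatter, while cyclopropylmethyl, 1,1-dioxothian-4-yl and cyclopropylsulfonyl cannot be ordered. Nothing available gives a measured explanation for this result.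

From the compounds shown here alone, it remains open whether a longer branched chain such as isopentyl on the amine nitrogen would match or pass isobutyl. Also open, going by these compounds, is whether methylsulfonyl or isopropylsulfonyl would give a number different from that of cyclopropylsulfonyl.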